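Fluoro in place of hydrogen on compound 2

The compounds below may be only part of what the source reports. "The series", "measured", "known", "first", "only" and "open" are said of these compounds alone.

compound 1 `Cc1ccnc(/C(N)=N/NC(=S)N2CCSCC2)c1`: 75.3%
compound 2 `N/C(=N\NC(=S)N1CCSCC1)c1ccccn1`: 81.3%
compound 3 `N/C(=N\NC(=S)N1CCCC1)c1ccccn1`: 85.2%

Of the compounds shown here, three have been tested in a functional assay on A-431 cells (Homo sapiens) for cytotoxicity, read by MTT assay, with a stated time of 72 h, tested at 30 uM; a lower number here means less inhibition of growth, a higher number more inhibition of growth at the concentration tested. Compound 2 sits between the other two: the step of a number 6 percentage points higher from compound 1 to compound 2 (within the scatter) and the step of a number 3.9 percentage points higher from compound 2 to compound 3 (within the scatter) are both small, so the three numbers are not separated by the scatter. Compound 4 `N/C(=N\NC(=S)N1CCSCC1)c1ccc(F)cn1` differs from compound 2 by fluoro in place of hydrogen on an aromatic carbon. Neither measured step involves a fluoro group, so nothing directly bears on this change; the two steps seen so far, a change on the same ring and a change at the thiocarbonyl carbon, were both within the scatter. No step beyond the scatter is therefore expected in this assay for compound 4; the expected step of a number 0.3 percentage points lower from compound 2 to compound 4 (within the scatter) is small. Compound 4 is estimated at 81%, within 70% to 90%.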

Compound 4, percent growth inhibition at one concentration: 84.6%
The estimate for compound 4 lay 3.6 percentage points below the measured number; the measured number falls inside the stated range.
By their numbers in this assay, from the lowest: compounds 1, 2, 4 and 3 (each within the scatter of the next).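

In this assay, fluoro in place of hydrogen on the aromatic carbon two atoms from the ring nitrogen and para to a large group gives a number 3.3 percentage points higher from compound 2 to compound 4 (within the scatter). Going by these compounds alone, this is the first reading at this carbon, and it shows that the fluoro group here produces no step beyond the scatter. No evidence on the cause of this result is available.

As far as these compounds go, whether a methoxy or an amine group on this carbon would also stay within the scatter of compound 2 remains open. So does the effect of fluoro here when pyrrolidin-1-yl, as in compound 3, stands on the thiocarbonyl carbon.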